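Three limits and a fluorophenyl exchange

The compounds below may be only part of what the source reports. "The series", "measured", "known", "first", "only" and "open" are said of these compounds alone.

Compound 1 `C=C[C@@](C)(/C=C/c1ccc(O)c(/C=C/C(=O)OCC)c1)CCC=C(C)C`: > 36600 nM
Compound 2 `C=C[C@@](C)(/C=C/c1ccc(O)c(/C=C/C(=O)OCc2ccccc2)c1)CCC=C(C)C`: > 36600 nM
Compound 3 `C=C[C@@](C)(/C=C/c1ccc(O)c(/C=C(\C)C(=O)OCC)c1)CCC=C(C)C`: > 36600 nM

All three compounds were tested in an ADME assay on HEK293 cells (Homo sapiens) for cytotoxicity, with a stated time of 72 h (a lower number here means that less compound is needed, a higher number that more compound is needed for the effect), and each entry is a limit of the assay, not a number. Compound 3 has no number of its own: it gives > 36600 nM, which is a limit. The same holds across the set, with the limit of > 36600 nM in this assay, at which 3 of the 3 values shown sit.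

Compound 4 `C=C[C@@](C)(/C=C/c1ccc(O)c(/C=C/c2ccc(F)cc2)c1)CCC=C(C)C` keeps the shared core but differs from compound 3 in one place: 2-(4-fluorophenyl)ethenyl in place of 2-(ethoxycarbonyl)prop-1-en-1-yl on an aromatic carbon. A 2-(4-fluorophenyl)ethenyl stands in place of 2-(ethoxycarbonyl)prop-1-en-1-yl on an aromatic carbon, ortho to a hydroxy group and meta to a large group.

Within the data shown here, two measured steps bear on this change, though only in part: a step that the two limits leave unreadable from compound 1 to compound 2 and a step that the two limits leave unreadable from compound 1 to compound 3. Neither has a readable size, and both keep the carbonyl group that compound 4 loses. Among the measured compounds shown here, they therefore support no step of a definite size in this assay. The expected at least 1.1-fold lower number from compound 3 to compound 4 (0.04 log units; that floor lies within the scatter) is small and uncertain, with a lower number the only direction that could be read. For compound 4 the estimate is 33000 nM, with an expected range from 12000 nM to 60000 nM.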

Compound 4, half-maximal effective concentration: > 36600 nM
Compound 4 gave a limit, no number (the forecaster's own chance of this, stated with the estimate: 65%); at least 1.1-fold (0.04 log units) between middle value and limit.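

In this assay compound 4 gives > 36600 nM, which is a limit and not a number. Among these compounds, no step from compound 1, compound 2 or compound 3 to compound 4 can be read, since all four compounds stand at the same limit: the limit of > 36600 nM in this assay, at which 4 of the 4 values shown sit. The compounds shown leave open what concentration any of them would need for the effect, and whether the exchanges change it.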